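The compounds below may be only part of what the source reports. "The series", "measured", "known", "first", "only" and "open" are said of these compounds alone.

Compound 1 `Cc1cc(COc2ccccc2)nc(-c2ccccn2)n1` is the reference point of this small set. In a functional assay on cells for antagonist activity at Free fatty acid receptor 1 (Homo sapiens), read by TR-FRET and inositol phosphate accumulation, with a stated time of 2 h (a higher number here means a weaker inhibitor, a lower number a stronger inhibitor), compound 1 gives 794 nM, the lowest of the two numbers recorded, with compound 2 as its nearest neighbour. Compound 2 `Cc1cc(COc2cccc(C#N)c2)nc(-c2ccccn2)n1` gives 2510 nM in this assay, a change of a 3.2-fold higher number from compound 1 to compound 2 (0.50 log units; beyond the scatter). Compound 3 `Cc1cc(COc2ccccc2S(C)(=O)=O)nc(-c2ccccn2)n1` is recorded only as a limit of this assay, > 39800 nM, and no number is available for it. This is the case of the limit of > 39800 nM in this assay, at which 1 of the 3 values shown sits, which fixes an at least 50-fold higher number from compound 1 to compound 3 (1.70 log units; beyond the scatter).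

Compound 4 `Cc1cc(COc2ccc(S(C)(=O)=O)cc2)nc(-c2ccccn2)n1` takes the same group as compound 3 but at another place on the ring: methylsulfonyl in place of hydrogen on an aromatic carbon, on an aromatic carbon of a six-membered aromatic ring of carbon only, para to a large group. The two measured steps both point the same way. The cyano step a 3.2-fold higher number from compound 1 to compound 2 (0.50 log units; beyond the scatter) was modest; the methylsulfonyl step an at least 50-fold higher number from compound 1 to compound 3 (1.70 log units; beyond the scatter) was large. For compound 4 a clearly higher number than for compound 1 in this assay is therefore expected, though the different position leaves its size uncertain. Compound 4 is estimated at 10000 nM, within 2500 nM to 40000 nM. That would amount to an expected step of a 13-fold higher number from compound 1 to compound 4 (1.10 log units; beyond the scatter).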

Compound 4, half-maximal inhibitory concentration: > 39800 nM
Compound 4 gave a limit, no number; the forecaster's own chance of this, stated with the estimate: 30%; middle value at least 3.9-fold (0.59 log units) away from the limit.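

Compound 4 shows that the large rise seen with methylsulfonyl is not confined to one place on the ring: with the group on an aromatic carbon para to a large group, this assay gives an at least 50-fold higher number from compound 1 to compound 4 (1.70 log units; beyond the scatter), and this step rests on a limit, not a number. The earlier compounds shown here showed this change at only one place, whereas now two different places on the same ring both end without a measurable value. Compound 3 and compound 4 carry the same limit, so they cannot be put in order, and neither place can be called the more damaging for this group: the limit of > 39800 nM in this assay, at which 2 of the 4 values shown sit.

The compounds shown leave open whether this place tolerates any substituent, since only hydrogen and methylsulfonyl are seen there, and a smaller group such as methyl, methoxy or a single fluorine atom could behave quite differently. From the compounds shown here alone, it also remains open how the nitrile of compound 2 would read at this place, and whether an amine or a carboxylic acid on this carbon would keep a measurable value.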